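Benzylamino variation on a bis(trifluoromethyl)benzenesulfonamide series

The source may hold more compounds than are shown below. What is called first, only, known or untested is meant among the compounds shown, and "the series" means these compounds.

Measured compounds:
compound 1 `O=S(=O)(NCCCNCc1ccccc1Cl)c1cc(C(F)(F)F)cc(C(F)(F)F)c1`: 9300 nM
compound 2 `O=S(=O)(NCCCNCc1ccc(Cl)c(Cl)c1)c1cc(C(F)(F)F)cc(C(F)(F)F)c1`: 1500 nM
compound 3 `O=S(=O)(NCCCNCc1ccc(-c2ccccc2)cc1)c1cc(C(F)(F)F)cc(C(F)(F)F)c1`: 2600 nM

All three share one core and differ only in the aryl group on the amine-bound chain carbon; all were read in a functional assay on A2780 cells (Homo sapiens) for inhibition, read by MTT assay, with a stated time of 72 h; on this read-out lower numbers stand for stronger inhibition of growth and higher numbers for weaker inhibition of growth. Compound 1 stands highest of the three numbers in this assay, with compound 3 nearer to it and compound 2 furthest. Among the compounds with values here, the one single-point step recorded, a 6.2-fold lower number from compound 1 to compound 2 (0.79 log units; beyond the scatter), is modest and beyond the scatter. Compound 4 `COc1ccc(CNCCCNS(=O)(=O)c2cc(C(F)(F)F)cc(C(F)(F)F)c2)cc1` is not yet measured; it differs from compound 1 as follows: 4-methoxyphenyl in place of 2-chlorophenyl on a saturated chain carbon bound to an amine nitrogen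

Within the data shown here, the step to compound 2 suggests that moving away from 2-chlorophenyl lowers the number, and compound 3 also sits below compound 1, though no step is recorded for that pair. Compound 4 is expected to improve on compound 1 by roughly a 2.3-fold lower number from compound 1 to compound 4 (0.37 log units; beyond the scatter), a step near the edge of the scatter. Compound 4 is therefore estimated at 4000 nM, range 1500 nM to 10000 nM.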

Compound 4, concentration for 50% growth inhibition: 1700 nM
Estimate against measurement, compound 4: 2.4-fold (0.37 log units) above; measured number inside the range.
By their numbers in this assay, from the lowest: compounds 2, 4 and 3 (each within the scatter of the next); then compound 1.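

In this assay, a second replacement of 2-chlorophenyl at this position clears the scatter, with a 5.5-fold lower number from compound 1 to compound 4 (0.74 log units; beyond the scatter) matching the size of the earlier step to compound 2. The replacements themselves do not separate: a 1.5-fold lower number from compound 3 to compound 4 (0.18 log units; within the scatter) and a 1.1-fold higher number from compound 2 to compound 4 (0.05 log units; within the scatter) both stay within the scatter. Compound 1 alone stands apart among the four, and the level of the others holds with chlorine present in compound 2 and absent in compound 4.

As far as these compounds go, how a longer chain or a carboxylic acid on the aryl group would read remains open. No measurement shown accounts for the distance of compound 1 from the others.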